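This account rests on a few compounds, and the source may have more. Where it says the series, first, only, none or still open, it means among the compounds named here.

Measured so far:
- compound 1, `Cc1cc(CCC(=O)O)ccc1-c1noc(-c2ccc(OC(C)C)c(C#N)c2)n1`; in a functional assay on CHO cells with sphingosine 1-phosphate receptor 2 (Homo sapiens) as the target, read by GTPgammaS binding (on this read-out lower numbers stand for an effect already at smaller amounts and higher numbers for an effect only at larger amounts of compound), compound 1 gives > 10000 nM, a limit of the assay and not a number.
- compound 2, `Cc1cc(CCC(=O)O)ccc1-c1noc(-c2ccc(OC(C)C(F)(F)F)c(C#N)c2)n1`; in this assay compound 2 gives > 10000 nM, again a limit of the assay.

Compound 2 therefore stands at the limit of > 10000 nM in this assay, at which 2 of the 2 values shown sit, with no measured number of its own. For the measured compounds named here, the one change recorded within the pair, a step that the two limits leave unreadable from compound 1 to compound 2, cannot be sized, since both ends of it sit at the limit.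

Compound 3, `Cc1cc(CCC(=O)O)ccc1-c1noc(-c2ccc(OCC(F)(F)F)c(C#N)c2)n1`, differs from compound 2 by hydrogen in place of methyl on a saturated chain carbon bound to an oxygen on an aromatic ring and a saturated chain carbon. Going by the values given here, no measured step bears on this change: the only step in the set, the one from compound 1 to compound 2, is unreadable, and the series shows no compound with a number in this assay at all. With two limits and nothing readable between them, there is no ground for expecting a step in either direction beyond the scatter; the expectation is that compound 3 will also fall at the limit.

Compound 3 is thus expected to give about 15000 nM, with a range from 4000 nM to 60000 nM. The step this expectation implies, a step that the limit leaves unreadable from compound 2 to compound 3, is expected to be none beyond the scatter.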

Compound 3, half-maximal effective concentration: > 10000 nM
Compound 3 gave a limit, no number; the forecaster's own chance of this, stated with the estimate: 80%; the middle value is on the limit's open side.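

In this assay, for the compounds shown here, no step among compound 1, compound 2 and compound 3 can be read, as all three rest on a limit of the assay and not on a number: the limit of > 10000 nM in this assay, at which 3 of the 3 values shown sit.

Still open, on these data alone, is how far these three compounds differ from one another, and whether any change on the oxygen-bound chain gives a measurable value.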